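A few compounds are considered here, and "the series" means these few. Any claim that something is new, unique, unknown or untested is made for them only; others in the source may bear on it.

Measured compounds:
compound 1, `Cc1ccc(S(=O)(=O)Nc2nnc(SCc3ccc(Cl)cc3)s2)cc1`, 68%;
compound 2, `COc1ccc(S(=O)(=O)Nc2nnc(SCc3ccccc3)s2)cc1`, 53%.

In a functional assay on MCF7 cells (Homo sapiens) for cytotoxicity, tested at 250 uM (on this read-out lower numbers stand for a stronger effect and higher numbers for a weaker effect at the one concentration tested), compound 2 gives 53%, the lowest of the two numbers and therefore the stronger effect of the pair. Its nearest neighbour on this read-out is compound 1, which in this assay gives 68%, a gap beyond the usual scatter. For the measured compounds named here, the two compounds differ in more than one place, so the numbers show only that compound 2 is the stronger of the two, not which part of the structure accounts for it.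

Compound 3, `COc1ccc(S(=O)(=O)Nc2nnc(SCc3ccc(Cl)cc3)s2)cc1`, has not yet been measured. It differs from compound 2 in one place: chloro in place of hydrogen on an aromatic carbon. Going by the values given here, no pair of measured compounds isolates this change, so its effect in this assay is unknown from the data here. The expected step of a number 4 percentage points higher from compound 2 to compound 3 (within the scatter) is small, with no direction better supported than the other. Compound 3 is estimated at 57%, within a range from 40% to 75%.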

Compound 3, a percentage reported as activity, at one concentration (the size of the read-out at that concentration, not a potency): 37%
The estimate for compound 3 lay 20 percentage points above the measured number; the measured number lies below the stated range.
By their numbers in this assay, from the lowest: compound 3; then compound 2; then compound 1.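

In this assay, chloro in place of hydrogen on the benzyl group gives a number 16 percentage points lower from compound 2 to compound 3 (beyond the scatter), so with the methoxy group held constant, 4-chlorobenzyl gives the stronger effect. With 4-chlorobenzyl held constant, methoxy in place of methyl on an aromatic carbon gives a number 31 percentage points lower from compound 1 to compound 3 (beyond the scatter), a larger step in the same direction of stronger effect. Each change can now be read on its own, which the first two compounds did not allow, but nothing measured here explains why either one lowers the number.

The compounds shown do not tell whether the chloro step would keep its size with methyl in place of methoxy. They also leave open how bromo or an amine at this same place on the benzyl group would compare with chloro.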